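Aryl swap on the aromatic nitrogen: acetamidophenyl analogue

The source may hold more compounds than are shown below. What is called first, only, known or untested is meant among the compounds shown, and "the series" means these compounds.

Compound 1 `N#CC1=C(N)Oc2c(N)cc3nc4ccccc4nc3c2C12C(=O)N(Cc1cnnn1-c1ccc(Cl)cc1)c1ccccc12` and compound 2 `N#CC1=C(N)Oc2c(N)cc3nc4ccccc4nc3c2C12C(=O)N(Cc1cnnn1-c1cccc(Br)c1)c1ccccc12` share one core. In an ADME assay on L02 cells (Homo sapiens) for antiproliferative activity, read by MTT assay, with a stated time of 48 h (on this read-out higher numbers stand for weaker inhibition and lower numbers for stronger inhibition), compound 1 gives > 50000 nM, which is a limit of the assay. In this assay compound 2 likewise gives only a limit, > 50000 nM. The step that the two limits leave unreadable from compound 1 to compound 2 therefore cannot be read. Compound 3 `CC(=O)Nc1ccc(-n2nncc2CN2C(=O)C3(C(C#N)=C(N)Oc4c(N)cc5nc6ccccc6nc5c43)c3ccccc32)cc1` carries 4-acetamidophenyl in place of 3-bromophenyl on an aromatic nitrogen. For the measured compounds named here, the only measured step bears on it solely as a pair of limits (the limit of > 50000 nM in this assay, at which 2 of the 2 values shown sit), so neither size nor direction can be drawn from it. Compound 3 is expected to remain at the limit as well, with an estimated 50000 nM between 20000 nM and 150000 nM. The expected step is a number no higher from compound 2 to compound 3 (the limit leaves the size open), not beyond the scatter.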

Compound 3, half-maximal inhibitory concentration: > 50000 nM
Compound 3 was reported as a limit (the forecaster's own chance of this, stated with the estimate: 80%); the middle value lies on the limit itself.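

The steps among compound 1, compound 2 and compound 3 cannot be read in this assay, since all three values are limits: the limit of > 50000 nM in this assay, at which 3 of the 3 values shown sit.

The compounds shown leave open whether the aryl group on the aromatic nitrogen affects this assay at all, and how far past that limit each compound lies.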